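Geometry of the double bond: compound 1 against compound 4

This account rests on a few compounds, and the source may have more. Where it says the series, first, only, none or still open, it means among the compounds named here.

Of the compounds shown here, three have numbers so far. Compound 1 `C=CCSS/C=C\C[S+]([O-])CCC` gives 23000 nM in a functional assay on WHCO1 cells (Homo sapiens) for antiproliferative activity, read by MTT assay, with a stated time of 48 h; a higher number here means a weaker inhibitor, a lower number a stronger inhibitor. Compound 2 `COc1ccc(C[S+]([O-])CC=CSSCc2ccc(F)cc2)cc1` gives 16000 nM, and compound 3 `CCC[S+]([O-])C/C=C\SSC` gives 26000 nM. Compound 1 stands second highest of the three numbers; its nearest neighbour is compound 3 and its furthest is compound 2, and both gaps lie within the scatter, so the three numbers give no ordering among them.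

Compound 4 `C=CCSS/C=C/C[S+]([O-])CCC` has not been measured. It differs from compound 1 in this way: the two compounds have the same atoms and bonds; at least one stereo element is drawn with a configuration in one of them and without one in the other: 1 of 2 stereo elements differ; a double bond is drawn Z in compound 1 and E in compound 4. Among the compounds with values here, the single step measured, a 1.1-fold higher number from compound 1 to compound 3 (0.05 log units; within the scatter), concerns a different change and does not bear on the geometry of the double bond; no measured pair addresses that geometry. With nothing to support a direction, the expectation for compound 4 is a step of no change at the digits printed from compound 1 to compound 4 (within the scatter), that is none beyond the scatter. Compound 4 is therefore estimated at 23000 nM, with a range from 11000 nM to 46000 nM.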

Compound 4, half-maximal inhibitory concentration: 37000 nM
Estimate against measurement, compound 4: 1.6-fold (0.21 log units) below, and the stated range covers the measured number.
By their numbers in this assay, from the lowest: compounds 2, 1, 3 and 4 (each within the scatter of the next, the first and the last beyond it).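

In this assay, the geometry of the double bond now has its first measured pair, with a 1.6-fold higher number from compound 1 to compound 4 (0.21 log units; within the scatter). The change from Z to E at this double bond therefore leaves the number within the scatter, and the earlier step, hydrogen in place of vinyl, could not show this. The reading carries one qualification in how the pair is drawn: the fact that one of compounds 1 and 4 is drawn with a defined configuration and the other without, at the place where they differ

Going by these compounds, it remains open whether the Z and E forms stay within the scatter of each other on any core other than that of compound 1, such as the one carrying the two benzyl-type groups of compound 2. On these data alone, it also remains open whether an amine or a carboxylic acid on the shared core would carry the number beyond the scatter.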